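The source may hold more compounds than are shown below. What is called first, only, known or untested is meant among the compounds shown, and "the series" means these compounds.

Measured in an ADME assay on BJ cells (Homo sapiens) for antiproliferative activity, with a stated time of 72 h; on this read-out higher numbers stand for an effect only at larger amounts of compound and lower numbers for an effect already at smaller amounts:
- compound 1, `COc1ccc(-c2c(Cl)c(=O)c3c(OC)cc(OC)cc3n2S(=O)(=O)c2ccc(OC)cc2)cc1`, gives 90000 nM.
- compound 2, `COC(=O)c1cc(=O)c2c(OC)cc(OC)cc2n1C`, gives only a limit of the assay, > 37900 nM.
- compound 3, `COc1ccc(-c2cc(=O)c3c(OC)cc(OC)cc3n2S(=O)(=O)c2ccc([N+](=O)[O-])cc2)cc1`, gives only a limit of the assay, > 29300 nM.

Compound 3 stands at a limit in this assay: the assay reports no number for it, only that its effect begins beyond the range covered, which is the limit of > 29300 nM in this assay, at which 1 of the 3 values shown sits. Compound 2 also stands at a limit, (the limit of > 37900 nM in this assay, at which 1 of the 3 values shown sits). For the measured compounds named here, compound 1 is the one compound with a number, and that number too is large. Going by the values given here, no two of the three measured compounds differ in one place only, so no measured step exists among them.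

Compound 4, `COc1ccc(-c2cc(=O)c3c(OC)cc(OC)cc3n2S(=O)(=O)c2ccc(C)cc2)cc1`, has not been measured. It differs from compound 3 by methyl in place of nitro on an aromatic carbon. Everything else in the two structures is the same. Among the compounds with values here, nothing among the measured compounds shows what this change does to the read-out. Since compound 3 sits at a limit, (the limit of > 29300 nM in this assay, at which 1 of the 3 values shown sits), the expected step is a step that the limit leaves unreadable from compound 3 to compound 4, none beyond the scatter. Compound 4 is estimated at 60000 nM, with a range from 20000 nM to 200000 nM, and it may well be reported only as a limit.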

Compound 4, half-maximal effective concentration: > 44800 nM
Compound 4 was reported as a limit; the forecaster's own chance of this, stated with the estimate: 70%; the middle value is on the limit's open side.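

In this assay compound 4 gives only a limit, > 44800 nM. Compound 3 likewise gives only a limit, > 29300 nM. With a limit on both sides, no step can be read between compound 3 and compound 4. The compounds shown leave open whether methyl in place of nitro on this aromatic carbon changes the read-out at all.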